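This account rests on a few compounds, and the source may have more. Where it says the series, first, only, none or still open, it means among the compounds named here.

Measured so far:
compound 1, `CC(C)OC(=O)N1CCC(O[C@H]2CC[C@H](Oc3ccc(S(C)(=O)=O)nc3)CC2)CC1`: 101%
compound 2, `CS(=O)(=O)c1cnc(O[C@H]2CC[C@H](OC3CCN(C(=O)OC4CCOC4)CC3)CC2)cn1`: 105%

Both compounds were tested in a functional assay on isolated protein for agonist activity at Glucose-dependent insulinotropic receptor (Homo sapiens), read by HTRF and cAMP accumulation; on this read-out higher numbers stand for larger maximal responses and lower numbers for smaller maximal responses. Compound 1 reaches 101%, and compound 2 reaches 105%; the gap between these two numbers lies within the usual scatter of this assay, so the two compounds cannot be told apart on this read-out, and both give a response about as large as the reference. Within the data shown here, no pair of measured compounds here differs in a single place, so no measured step is available to lean on.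

Compound 3, `CS(=O)(=O)c1cnc(O[C@H]2CC[C@H](OC3CCN(CC4(C(F)(F)F)CCCC4)CC3)CC2)cn1`, has not yet been measured. It differs from compound 2 in one place: a group of 10 heavy atoms (7 carbon, 3 fluorine; one five-membered non-aromatic ring of carbon only) in place of a group of 8 heavy atoms (5 carbon, 3 oxygen; one five-membered non-aromatic ring with 1 hetero atom), on an amine nitrogen in a ring. With the two measured compounds already at a full response, and without any measured step to guide the size of the change, the step of a number 10 percentage points lower from compound 2 to compound 3 (within the scatter) is expected to be small, at most a modest decrease that need not go beyond the scatter. Compound 3 is therefore expected to reach about 95%, with a range from 70% to 110%.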

Compound 3, largest response reached (Emax), in percent of the reference or control that the assay uses: 37%
The estimate for compound 3 lay 58 percentage points above the measured number, and the stated range ends above it.
By their numbers in this assay, from the lowest: compound 3; then compounds 1 and 2 (each within the scatter of the next).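

This position is not as tolerant as the first two compounds might suggest: on the amine nitrogen in a ring, the full response in this assay depends on which group is attached. Replacing ((oxolan-3-yl)oxy)carbonyl with the group of 10 heavy atoms, which has a five-membered ring of carbon only and three fluorines, gives a number 68 percentage points lower from compound 2 to compound 3 (beyond the scatter), so this single change separates the compounds clearly, unlike the gap between the two earlier numbers. Nothing shown here explains the loss of response.

The change replaces several features at once: the carbonyl, the oxygen atoms, the hetero atom in the ring and the hydrogen-bond acceptors all leave, while the fluorines enter, so these compounds cannot show which of these differences matters. A (cyclopentyloxy)carbonyl group on the same nitrogen would keep the carbonyl while removing the ring oxygen, and a cyclopentylmethyl group would test the carbon-only ring without either the carbonyl or the fluorines, so either could help to divide the step into its parts.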